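Replacing a Pyridine Ring with a Methylphenyl Ring

The source may report more compounds than this note shows. Statements on the series, on what has been measured and on what is new or still open speak of the compounds shown alone.

Compound 3 `CC(C)C[C@H](N)CN(C(=O)[C@@H]1C[C@H]1c1ccccc1)c1ccc(-c2ccncc2)cc1` is the weakest of the three measured compounds in a functional assay for agonist activity at G protein-coupled receptor 88 (Homo sapiens), read by HTRF and cAMP accumulation (a lower number here means that less compound is needed, a higher number that more compound is needed for the effect), where compound 3 gives 13000 nM. Compound 2 `CC[C@H](C)[C@H](N)CN(C(=O)[C@@H]1C[C@H]1c1nccs1)c1ccc(-c2ccccc2)cc1` gives 210 nM in this assay, and compound 1 `CCC(C)CNCCN(C(=O)[C@@H]1C[C@H]1c1ccccc1)c1ccc(-c2ccccc2)cc1` gives 4.7 nM in this assay. Compound 4 `Cc1ccc(-c2ccc(N(C[C@@H](N)CC(C)C)C(=O)[C@@H]3C[C@H]3c3ccccc3)cc2)cc1` is not yet measured; it differs from compound 3 in one place: 4-methylphenyl in place of pyridin-4-yl on an aromatic carbon. For the measured compounds named here, no measured pair shows this exact exchange. Both compounds that carry a ring of carbon only at this position sit far lower: compound 1 at 4.7 nM and compound 2 at 210 nM. On that basis a large drop is expected for compound 4, with the step from compound 3 to compound 4 estimated at a 43-fold lower number from compound 3 to compound 4 (1.64 log units; beyond the scatter). Compound 4 is expected at 300 nM, within 50 nM to 3000 nM.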

Compound 4, half-maximal effective concentration: 360 nM
For compound 4 the middle estimate is 1.2-fold (0.08 log units) below the measured one, within the range that was stated.
By their numbers in this assay, from the lowest: compound 1; then compounds 2 and 4 (each within the scatter of the next); then compound 3.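

For the compounds shown here, this pair gives the only direct reading at this position: with the rest of the molecule unchanged, 4-methylphenyl in place of pyridin-4-yl gives a 36-fold lower number from compound 3 to compound 4 (1.56 log units; beyond the scatter) in this assay. The activity therefore depends strongly on which ring stands here, though the exchange removes the ring nitrogen and adds a methyl at once. Nothing on hand explains the size of this step.

The compounds shown leave open how much of the step belongs to each of those two parts, which plain phenyl on the core of compound 4 would help to separate. On these data alone, how 4-methoxyphenyl or 4-chlorophenyl would behave here also remains open.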